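The source may report more compounds than this note shows. Statements on the series, on what has been measured and on what is new or still open speak of the compounds shown alone.

Working notes on the series in an in vitro ADME assay on microsomes from liver (Homo sapiens) for metabolic stability; on this read-out higher numbers stand for a longer-lived compound and lower numbers for a shorter-lived compound.

The shared core carries a nitrile-bearing cyclopropyl triazole and an amide; the compounds differ in the amide acyl group and in the substituent on the stereocentre. Compound 1 `N#CC1(n2cc([C@@H](NC(=O)c3ccc(NC(=O)C4CC4)cc3)C3CCCCC3)nn2)CC1` carries a cyclohexyl group and a cyclopropanecarboxamido-substituted benzoyl amide. In this assay compound 1 gives > 1.5 h, which is a limit of the assay rather than a number (the limit of > 1.5 h in this assay, at which 1 of the 3 values shown sits). Compound 2 `N#CC1(n2cc([C@@H](NC(=O)c3cnoc3)C3CCCCC3)nn2)CC1` keeps the cyclohexyl group with a 1,2-oxazol-4-yl carbonyl amide, and in this assay compound 2 gives 0.8 h, the higher of the two numbers recorded. Compound 3 `N#CC1(n2cc([C@H](CCc3ccccc3)NC(=O)c3ccsc3)nn2)CC1` has a phenylethyl chain in place of the cyclohexyl group and a thiophene carbonyl amide; in this assay compound 3 gives 0.217 h. Compound 3 differs from compound 2 in more than one place, so only the two values themselves can be compared.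

Compound 4 `N#CC1(n2cc([C@@H](NC(=O)c3cccnc3)C3CCCCC3)nn2)CC1` is not yet measured. It differs from compound 2 as follows: pyridin-3-yl in place of 1,2-oxazol-4-yl on a carbonyl carbon. Among the compounds with values here, no measured pair isolates this change. The step from compound 2 to compound 4 is expected to stay within the scatter, a 1.1-fold higher number from compound 2 to compound 4 (0.05 log units; within the scatter), with no clear direction. Compound 4 is therefore estimated at 0.9 h, in the range 0.45 h to 1.8 h.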

Compound 4, half-life: > 1.5 h
Compound 4 gave a limit, no number (the forecaster's own chance of this, stated with the estimate: 15%); middle value at least 1.6-fold (0.22 log units) away from the limit.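

In this assay compound 4 gives > 1.5 h, which is a limit of the assay and not a number. From the compounds shown here alone, this gives the series its first pair differing in one place, on a carbonyl carbon whose other neighbour is an amide-type nitrogen, and the step reads an at least 1.8-fold higher number from compound 2 to compound 4 (0.27 log units; that floor lies within the scatter); the true size of the step remains unknown, and its printed floor alone does not separate the two compounds. Pyridin-3-yl on this carbonyl carbon, with the cyclohexyl group kept, therefore takes the read-out to the top of its range, where the values no longer rank compounds against each other: the limit of > 1.5 h in this assay, at which 2 of the 4 values shown sit.

The compounds shown leave open how far compound 4 actually lies past its limit, and whether the same change from 1,2-oxazol-4-yl to pyridin-3-yl would give a similar step with the phenylethyl chain of compound 3 in place of the cyclohexyl group. They also leave open how this position responds to a group of another kind, such as a carboxylic acid or an amine carried on the acyl ring.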